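The source may report more compounds than this note shows. Statements on the series, on what has been measured and on what is new or still open speak of the compounds shown alone.

Within the data shown here, in a functional assay on Caco-2 cells (Homo sapiens) for cytotoxicity, with a stated time of 48 h (on this read-out higher numbers stand for weaker inhibition and lower numbers for stronger inhibition), two compounds sharing a core have numbers so far. Compound 2 (`COc1cc(O)c(C(=O)/C=C/c2ccccc2OC)c(OC)c1`) gives 10000 nM there. Among the measured compounds shown here, compound 1 (`COc1cc(OC)c(C(=O)/C=C/c2ccccc2SC)c(OC)c1`) gives 8800 nM in the same test, and the two values lie within the scatter of each other, so compound 2 has no separation from its only measured neighbour. Compound 3 (`COc1cc(O)c(C(=O)/C=C/c2ccccc2SC)c(OC)c1`) is still unmeasured. It departs from compound 2 in one place, with methylsulfanyl in place of methoxy on an aromatic carbon, ortho to a large group: methylsulfanyl in place of methoxy on an aromatic carbon is the whole difference. For the measured compounds named here, no measured pair isolates this exchange. Compound 1 carries the methylsulfanyl group but also differs from compound 3 elsewhere, so it offers only indirect guidance. With compound 1 at 8800 nM and compound 2 at 10000 nM in the same range, no shift beyond the scatter is expected in this assay and neither direction is favoured. The estimated step of a 1.1-fold lower number from compound 2 to compound 3 (0.05 log units; within the scatter) is accordingly expected to be small. Compound 3 is expected at 9000 nM with 3500 nM to 22000 nM (the estimated range).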

Compound 3, half-maximal inhibitory concentration: 9600 nM
The estimate for compound 3 lay 1.1-fold (0.03 log units) below the measured number; low and high end bracket the measured number.
By their numbers in this assay, from the lowest: compounds 1, 3 and 2 (each within the scatter of the next).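

The exchange of methoxy for methylsulfanyl on an aromatic carbon, ortho to a large group, is now isolated in a single pair: in this assay it gives a 1.0-fold lower number from compound 2 to compound 3 (0.02 log units; within the scatter), so with the rest of the structure held fixed, this change does not separate the two compounds. Among these compounds, a second single change can now be read as well, hydrogen in place of methyl on an oxygen on an aromatic ring, which gives a 1.1-fold higher number from compound 1 to compound 3 (0.04 log units; within the scatter) and likewise stays within the scatter, so with methylsulfanyl in place, neither this exchange nor the first moves the number beyond what repeated measurement would produce. No measured information is available to explain these results.

The compounds shown leave open whether any group at this place would move the number beyond the scatter, for example a chlorine atom, an amine or a longer chain such as ethylsulfanyl. They also leave open whether the two exchanges would stay within the scatter on a different core or in a different test.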